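Chain extension at the sulfur of the chloromethyl ketone series

A few compounds are considered here, and "the series" means these few. Any claim that something is new, unique, unknown or untested is made for them only; others in the source may bear on it.

Measured in a functional assay on MOLT-3 cells (Homo sapiens); on this read-out higher numbers stand for weaker inhibition and lower numbers for stronger inhibition:
compound 1 `CSC[C@H](NC(C)=O)C(=O)CCl` gives 80800 nM
compound 2 `CCSC[C@H](NC(C)=O)C(=O)CCl` gives 99900 nM
compound 3 `CCCCCCCCSC[C@H](NC(C)=O)C(=O)CCl` gives 4100 nM

Compound 3 has the lowest number of the three, and its gap to compound 1 as well as to compound 2 lies beyond the scatter. Compound 4 `CCCCCCCCCCCCCSC[C@H](NC(C)=O)C(=O)CCl` differs from compound 3 by pentyl in place of hydrogen on a saturated chain carbon, eight bonds along the chain from a sulfur. The step that bears on this is a 24-fold lower number from compound 2 to compound 3 (1.39 log units; beyond the scatter), a large lowering brought by a lengthened chain at the same position, whereas the shorter lengthening in a 1.2-fold higher number from compound 1 to compound 2 (0.09 log units; within the scatter) stayed within the scatter. Whether a still longer chain keeps gaining is not shown by any measured pair, so a smaller further lowering is expected, a 2.7-fold lower number from compound 3 to compound 4 (0.44 log units; beyond the scatter). For compound 4 the estimated value in this assay is 1500 nM, within a range from 400 nM to 6000 nM.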

Compound 4, half-maximal inhibitory concentration: > 100000 nM
Compound 4: no number, only a limit; the forecaster's own chance of this, stated with the estimate: 5%; middle value at least 66-fold (1.82 log units) from the limit.
By their numbers in this assay, from the lowest: compound 3; then compounds 1 and 2 (each within the scatter of the next). At a limit, above all of these: compound 4.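

In this assay compound 4 carries no number, only a limit: the limit of > 100000 nM in this assay, at which 1 of the 4 values shown sits. The gain from lengthening at this position therefore does not continue: after a 24-fold lower number from compound 2 to compound 3 (1.39 log units; beyond the scatter), pentyl in place of hydrogen, eight bonds along the chain from a sulfur, gives an at least 24-fold higher number from compound 3 to compound 4 (1.38 log units; beyond the scatter). Of the four compounds, only compound 3 stands clear at the low end, so the longest chain shown does not give the lowest number.

Where between the chains of compound 3 and compound 4 the number turns upward remains open. Also open, on these data alone, is how a chain ending in an amine or a carboxylic acid would read at this position.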